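Chain lengthening on the ring nitrogen of the shared core

A few compounds are considered here, and "the series" means these few. Any claim that something is new, unique, unknown or untested is made for them only; others in the source may bear on it.

Compound 3 `COc1cc(-c2nccn2C(C)C)cc(OC)c1OC` carries an isopropyl group on an aromatic nitrogen of the shared core. In a functional assay on HT-29 cells (Homo sapiens) for antiproliferative activity, read by MTT assay, with a stated time of 72 h (a higher number here means a weaker inhibitor, a lower number a stronger inhibitor), compound 3 gives only a limit, > 100000 nM. Its two neighbours vary the same position. Compound 1 `CCn1ccnc1-c1cc(OC)c(OC)c(OC)c1` bears an ethyl group there, and in this assay compound 1 also gives a limit, > 100000 nM. Compound 2 `CCCn1ccnc1-c1cc(OC)c(OC)c(OC)c1` bears a propyl group, and in this assay compound 2 likewise reaches only the limit, > 100000 nM. The three steps among them are therefore not readable: a step that the two limits leave unreadable from compound 1 to compound 2, a step that the two limits leave unreadable from compound 1 to compound 3 and a step that the two limits leave unreadable from compound 2 to compound 3. All of this rests on (the limit of > 100000 nM in this assay, at which 3 of the 3 values shown sit).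

Compound 4 `CCCCn1ccnc1-c1cc(OC)c(OC)c(OC)c1` is the next member: butyl in place of isopropyl on an aromatic nitrogen. Each measured step bears on it, as each also changes only the chain on the same aromatic nitrogen, yet none gives a size. No number in the set falls inside the measurable window, so the expectation for compound 4 is that it too will sit at the limit. The step that the limit leaves unreadable from compound 3 to compound 4 is expected to be unreadable in the same way. Compound 4 is estimated at 150000 nM in this assay, with a range from 30000 nM to 1000000 nM, and the most likely outcome is again a limit rather than a number.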

Compound 4, half-maximal inhibitory concentration: > 100000 nM
Compound 4 ended at the assay's limit (the forecaster's own chance of this, stated with the estimate: 80%); the middle value does not contradict the limit.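

Compound 4 gives only a limit in this assay, > 100000 nM. Its steps from compound 1, compound 2 and compound 3 therefore cannot be read, and the ethyl, propyl, isopropyl and butyl chains cannot be ranked: the limit of > 100000 nM in this assay, at which 4 of the 4 values shown sit. The compounds shown leave open whether any chain on this aromatic nitrogen gives a measurable value in this assay.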